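Nitro to dimethylamino swap, carried onto a second core

The source may report more compounds than this note shows. Statements on the series, on what has been measured and on what is new or still open speak of the compounds shown alone.

Two cores carry the same pair of substituted benzoyl groups on their amide nitrogen. Compound 1 `N#Cc1cccc(S(=O)(=O)Oc2ccc(-c3cncn3C3CCN(C(=O)c4ccc([N+](=O)[O-])cc4)CC3)cc2)c1` and compound 2 `CN(C)c1ccc(C(=O)N2CCC(n3cncc3-c3ccc(OS(=O)(=O)c4cccc(C#N)c4)cc3)CC2)cc1` share one core; in an assay on THP-1 cells for antagonist activity at P2X purinoceptor 7 (Homo sapiens), read by ELISA, with a stated time of 30 min (a lower number here means a stronger inhibitor, a higher number a weaker inhibitor), compound 1 gives 13 nM and compound 2 gives 10 nM. The change between them, (dimethylamino in place of nitro on an aromatic carbon), made a step of a 1.3-fold lower number from compound 1 to compound 2 (0.11 log units; within the scatter). Compound 3 `O=C(c1ccc([N+](=O)[O-])cc1)N1CCN(c2cc(=O)[nH]c(=O)n2Cc2ccc(OS(=O)(=O)c3cccc4cnccc34)cc2)CC1` is built on a different core; the difference between the two cores is not broken down here. In this assay compound 3 gives 32 nM, the highest of the three numbers, beyond the scatter from both compound 1 and compound 2.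

Compound 4 `CN(C)c1ccc(C(=O)N2CCN(c3cc(=O)[nH]c(=O)n3Cc3ccc(OS(=O)(=O)c4cccc5cnccc45)cc3)CC2)cc1` is not yet measured. It differs from compound 3 by dimethylamino in place of nitro on an aromatic carbon, the same change as from compound 1 to compound 2, at a place described in the same words. Within the data shown here, only that one earlier example of the step exists here, so the expectation rests on it and on the value of compound 3. The step from compound 1 to compound 2 stayed within the scatter, so compound 4 is expected to land close to compound 3 rather than apart from it. The expected step is a 1.1-fold lower number from compound 3 to compound 4 (0.06 log units; within the scatter). The estimate for compound 4 in this assay is 28 nM, with a range from 12 nM to 65 nM to allow for the second core carrying the step differently.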

Compound 4, half-maximal inhibitory concentration: 1.33 nM
Compound 4: the middle estimate sits 21-fold (1.32 log units) above what was measured; the measured number lies below the stated range.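

In this assay, putting dimethylamino in place of nitro on the core of compound 3 gave a step of a 24-fold lower number from compound 3 to compound 4 (1.38 log units; beyond the scatter), and the same change on the core of compound 1 did not behave alike: the same change on two cores in this assay, a 1.3-fold lower number (0.11 log units; within the scatter) from compound 1 to compound 2 and a 24-fold lower number (1.38 log units; beyond the scatter) from compound 3 to compound 4, 19-fold (1.27 log units) apart, beyond the scatter of two such steps. In these two pairs, then, the size of the step depends on the core carrying it, so a step within the scatter on one core gave no reliable estimate for the other. This does not show which part of the core sets the difference or why the step is large on one core only, and two pairs are too few to establish a rule for the series, since the two cores differ in more than one place and that difference is not broken down here.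

As far as these compounds go, it remains open whether the large step belongs to dimethylamino specifically or would also appear with a primary amine or a methoxy group on the same aromatic carbon of the core of compound 3. From the compounds shown here alone, it is equally open whether a third core would follow compound 3 and compound 4, or compound 1 and compound 2.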